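Swapping a hydroxypropyl carbonate for an aminopropyl carbamate

The source may report more compounds than this note shows. Statements on the series, on what has been measured and on what is new or still open speak of the compounds shown alone.

Compound 2 `Cc1cn(C2CC(N=[N+]=[N-])C(COC(=O)OCCCO)O2)c(=O)[nH]c1=O` is the least lipophilic of three measured compounds in a physicochemical assay for lipophilicity (on this read-out lower numbers stand for lower lipophilicity and higher numbers for higher lipophilicity), giving -0.98. Compound 1 `CCCCOC(=O)OCC1OC(n2cc(C)c(=O)[nH]c2=O)CC1N=[N+]=[N-]` gives 1.02, and compound 3 `Cc1cn(C2CC(N=[N+]=[N-])C(COC(=O)OCCCC(=O)OC(C)(C)C)O2)c(=O)[nH]c1=O` gives 1.14. The change a number 2.00 log units lower from compound 1 to compound 2 (beyond the scatter) and the change a number 2.12 log units higher from compound 2 to compound 3 (beyond the scatter) are both large, while a number 0.12 log units higher from compound 1 to compound 3 (within the scatter) stays within the scatter. Compound 4 `Cc1cn(C2CC(N=[N+]=[N-])C(COC(=O)NCCCN)O2)c(=O)[nH]c1=O` differs from compound 2 by (3-aminopropyl)amino in place of 3-hydroxypropoxy on a carbonyl carbon. Among the measured compounds shown here, no measured step touches this change directly; the steps known here only show that a terminal hydroxy lowered the number and a tert-butoxycarbonyl raised it. A further drop in this assay is expected, so compound 4 is estimated at -1.8, between -2.9 and -0.7. The expected step is a number 0.82 log units lower from compound 2 to compound 4 (beyond the scatter).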

Compound 4, partition coefficient: -1.19
The estimate for compound 4 lay 0.61 log units below the measured number; measured number inside the range.
By their numbers in this assay, from the lowest: compounds 4 and 2 (each within the scatter of the next); then compounds 1 and 3 (each within the scatter of the next).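

In this assay, (3-aminopropyl)amino in place of 3-hydroxypropoxy on a carbonyl carbon gives a number 0.21 log units lower from compound 2 to compound 4 (within the scatter) and so leaves the number at this position essentially unchanged. Measured against the butoxy group, the same chain gives a number 2.21 log units lower from compound 1 to compound 4 (beyond the scatter) and so sits as far from it as the hydroxy chain does. No evidence is available to explain why the two chains read alike.

The two groups differ at both the linking atom and the chain end, so the contribution of each swap stays unseparated. A chain ending in a carboxylic acid, or a longer chain ending in an amine, also remains to be placed in this assay.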